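A few compounds are considered here, and "the series" means these few. Any claim that something is new, unique, unknown or untested is made for them only; others in the source may bear on it.

Compound 3 `Cc1cccc(C)c1CNC1(CCC(C)(C)C)C(=O)C(C2=NS(=O)(=O)c3cc(NS(C)(=O)=O)ccc3N2)=C(O)c2ccccc21` gives 53.7% in an in vivo ADME assay on the whole organism (strain Sprague-Dawley) for pharmacokinetics, with Rattus norvegicus as the target, at a dose of 5 mg/kg by the oral route; a lower number here means that a smaller share of the oral dose reaches the circulation, a higher number that a larger share of the oral dose reaches the circulation. Compound 1 `Cc1cccc(C)c1CN[C@]1(CCC(C)(C)C)C(=O)C(C2=NS(=O)(=O)c3cc(NS(C)(=O)=O)ccc3N2)=C(O)c2ccccc21` gives 55.9% in this assay; the step of a number 2.2 percentage points lower from compound 1 to compound 3 (within the scatter) rests on (the fact that one of compounds 1 and 3 is drawn with a defined configuration and the other without, at the place where they differ). Compound 2 `CC(C)CC[C@@]1(NCc2ccccc2)C(=O)C(C2=NS(=O)(=O)c3cc(NS(C)(=O)=O)ccc3N2)=C(O)c2ccccc21` gives 13.3%. Compound 3 therefore stands second highest of the three numbers, close to compound 1 and far above compound 2. Compound 4 `Cc1ccc(CNC2(CCC(C)(C)C)C(=O)C(C3=NS(=O)(=O)c4cc(NS(C)(=O)=O)ccc4N3)=C(O)c3ccccc32)cn1` carries 6-methylpyridin-3-yl in place of 2,6-dimethylphenyl on a saturated chain carbon bound to an amine nitrogen. Among the compounds with values here, none of the measured steps touches a change of this kind: the only single-place step concerns how a stereocentre is drawn, and compound 2 differs from compound 3 in more than one place, so its value alone gives no guide. The reader therefore expects for compound 4 a step of a number 8.7 percentage points lower from compound 3 to compound 4 (within the scatter) of no size beyond the scatter. The estimate for compound 4 is 45%, within a range from 20% to 70%.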

Compound 4, oral bioavailability: 0%
Estimate against measurement, compound 4: 45 percentage points above; the measured number lies below the stated range.
By their numbers in this assay, from the lowest: compound 4; then compound 2; then compounds 3 and 1 (each within the scatter of the next).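

In this assay, within the data shown here, the exchange on the saturated chain carbon bound to an amine nitrogen gives a large step, a number 53.7 percentage points lower from compound 3 to compound 4 (beyond the scatter), whereas the only earlier single-place step concerned how a stereocentre was drawn. This shows that a single exchange of 6-methylpyridin-3-yl for 2,6-dimethylphenyl at this place can alter the read-out far beyond the scatter. Nothing measured here accounts for the size of this step.

The compounds shown leave open which part of the exchange carries the step, the ring nitrogen or the different methyl substitution. A 4-methylphenyl group at this place would help to separate the two.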